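Swapping imidazole for thiophene on the benzylic aryl ring

This account rests on a few compounds, and the source may have more. Where it says the series, first, only, none or still open, it means among the compounds named here.

Of the compounds shown here, three sharing one core have been tested in an assay on isolated protein for inhibition of ubiquitin carboxyl-terminal hydrolase 7 (Homo sapiens), with stated times of 30 min and 2 h; a lower number here means a stronger inhibitor, a higher number a weaker inhibitor. Compound 1 `Cn1nc2c(=O)n(CC3(O)CCN(Cc4ccc(-n5ccnc5)cc4Cl)CC3)cnc2c1-c1ccc(CN)cc1` gives 228 nM and stands at the highest of the three numbers. Compound 2 `Cn1nc2c(=O)n(CC3(O)CCN(Cc4ccc(-c5ccco5)cc4Cl)CC3)cnc2c1-c1ccc(Cl)cc1` gives 143 nM, and compound 3 `Cn1nc2c(=O)n(CC3(O)CCN(Cc4ccc(-c5ccco5)cc4Cl)CC3)cnc2c1-c1ccc(C(=N)N)cc1` gives 87.5 nM. Among the measured compounds shown here, the only single-point step among them, a 1.6-fold lower number from compound 2 to compound 3 (0.21 log units; within the scatter), concerns the aryl group attached to the core, not the benzyl side chain, and is within the scatter. For the measured compounds named here, compound 1 and compound 2 differ in two places at once, so their values show only that compound 1 sits within the scatter of compound 2 and beyond it relative to compound 3.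

Compound 4 `Cn1nc2c(=O)n(CC3(O)CCN(Cc4ccc(-c5ccsc5)cc4Cl)CC3)cnc2c1-c1ccc(CN)cc1` differs from compound 1 in one place: thiophen-3-yl in place of 1H-imidazol-1-yl on an aromatic carbon. Going by the values given here, no measured step touches this position, so nothing in the data points to a change in either direction. The estimate for compound 4 is therefore set close to compound 1, at 180 nM with a range from 70 nM to 460 nM, meaning an expected step of a 1.3-fold lower number from compound 1 to compound 4 (0.10 log units; within the scatter).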

Compound 4, half-maximal inhibitory concentration: 59.5 nM
Compound 4: the middle estimate sits 3.0-fold (0.48 log units) above what was measured; the measured number lies below the stated range.
By their numbers in this assay, from the lowest: compounds 4, 3, 2 and 1 (each within the scatter of the next, the first and the last beyond it).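

Thiophen-3-yl in place of 1H-imidazol-1-yl, on the aromatic carbon para to a large group, gives a 3.8-fold lower number from compound 1 to compound 4 (0.58 log units; beyond the scatter) in this assay with nothing else in compound 1 changed. Among the compounds shown here, this is the first step measured at this position, and it shows that the number responds to which five-membered aromatic ring sits there, even though both rings have the same count of heavy atoms. The entering ring has sulfur in place of the two nitrogens and one hydrogen-bond acceptor rather than two, but no measurement here explains the lower number.

On these data alone, whether the sulfur or the loss of the ring nitrogens matters more remains open, and a phenyl ring, a pyridine ring or thiophen-2-yl at this position would help separate the two. As far as these compounds go, it also remains open whether the same swap gives a similar step when the aminomethyl group of compound 4 is replaced by a chloro group.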